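The source may hold more compounds than are shown below. What is called first, only, known or untested is meant among the compounds shown, and "the series" means these compounds.

Measured in a functional assay on PC-3 cells (Homo sapiens) for antiproliferative activity, read by MTT assay, with a stated time of 48 h; a higher number here means a weaker inhibitor, a lower number a stronger inhibitor:
- compound 1 `CCC(C)C(NC(=O)c1ccc(C(CC)(CC)c2ccc(OCCC(O)(CC)CC)c(C)c2)n1CC)C(=O)OC`: > 50000 nM
- compound 2 `CCC(C)C(CO)NC(=O)c1ccc(C(CC)(CC)c2ccc(OCCC(O)(CC)CC)c(C)c2)n1CC`: 28400 nM

Compound 1 stands at > 50000 nM, which is a limit of the assay and not a number. For the measured compounds named here, compound 2, at 28400 nM, holds the only number. Compound 3 `CCn1c(C(=O)N(C)CCO)ccc1C(CC)(CC)c1ccc(OCCC(O)(CC)CC)c(C)c1` differs from it on the carbonyl carbon: (2-hydroxyethyl)(methyl)amino in place of (1-(hydroxymethyl)-2-methylbutyl)amino on a carbonyl carbon. Going by the values given here, the one measured step, an at least 1.7-fold lower number from compound 1 to compound 2 (0.24 log units; that floor lies within the scatter), touches only the hydroxymethyl of the leaving group, and no measured step covers the full exchange. The expected change is a 1.1-fold higher number from compound 2 to compound 3 (0.02 log units; within the scatter), with nothing beyond the scatter anticipated in this assay. Compound 3 is estimated at 30000 nM, within an expected range of 12000 nM to 50000 nM.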

Compound 3, half-maximal inhibitory concentration: 3090 nM
Compound 3: middle estimate off by 9.7-fold (0.99 log units), on the high side; the whole stated range lies above it.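

In this assay, for the compounds shown here, the group on the carbonyl carbon is the first place where a change moves beyond the scatter: (2-hydroxyethyl)(methyl)amino in place of (1-(hydroxymethyl)-2-methylbutyl)amino gives a 9.2-fold lower number from compound 2 to compound 3 (0.96 log units; beyond the scatter) in this pair. The exchange also gives an at least 16-fold lower number from compound 1 to compound 3 (1.20 log units; beyond the scatter) as a floor and not a full size, since that step rests on a limit: the limit of > 50000 nM in this assay, at which 1 of the 3 values shown sits.

The step from compound 2 to compound 3 shortens the chain and puts a methyl on the amide nitrogen at once, and the compounds shown do not separate these two changes. A (2-hydroxyethyl)amino group, without that methyl, would divide them.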